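The compounds below may be only part of what the source reports. "The series", "measured", "known", "first", "only" and "open" are said of these compounds alone.

Of the compounds shown here, three built on one shared core have been measured in an assay on MDA-MB-231 cells for binding affinity to C-X-C chemokine receptor type 4 (Homo sapiens), read by immunofluorescence and microscopy, with stated times of 10 min and 30 min; a lower number here means that less compound is needed, a higher number that more compound is needed for the effect. Compound 1 `O=C(NCc1ccc(CNS(=O)(=O)c2ccccc2)cc1)c1ccc([N+](=O)[O-])cc1` gives 100 nM. Compound 2 `O=C(NCc1ccc(CNS(=O)(=O)c2ccccc2)cc1)c1c(Cl)cc(Cl)cc1Cl` gives 10 nM. Compound 3 `Cc1cccc(C(=O)NCc2ccc(CNS(=O)(=O)c3ccccc3)cc2)c1` gives 1000 nM, the highest of the three numbers: the step of a 10-fold higher number from compound 1 to compound 3 (1.00 log units; beyond the scatter) and the step of a 100-fold higher number from compound 2 to compound 3 (2.00 log units; beyond the scatter) both lie beyond the scatter, as does the step of a 10-fold lower number from compound 1 to compound 2 (1.00 log units; beyond the scatter). Compound 3 thus stands furthest from compound 2 and nearer to compound 1.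

Compound 4 `O=C(NCc1ccc(CNS(=O)(=O)c2ccccc2)cc1)c1ccccc1` follows from compound 3 by a single difference, (hydrogen in place of methyl on an aromatic carbon), so that the 3-methylphenyl on the carbonyl carbon becomes a plain phenyl. Among the compounds with values here, none of the measured steps removes a methyl alone; each replaces one whole aryl group by another, and those steps were modest to large. The measured steps therefore bear on the new change only loosely: they show that the aryl group on the carbonyl carbon matters in this assay, but not what a single methyl contributes. No large step beyond the scatter is expected in this assay from the removal of one carbon, in either direction.

The estimate for compound 4 in this assay is 600 nM, within a range from 150 nM to 3000 nM, which means an expected step of a 1.7-fold lower number from compound 3 to compound 4 (0.22 log units; within the scatter).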

Compound 4, effective concentration (reported as EC, without a stated level of effect): 1 nM
Beside the measured number, compound 4's estimate is 600-fold (2.78 log units) above it, and the stated range ends above it.
By their numbers in this assay, from the lowest: compound 4; then compound 2; then compound 1; then compound 3.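

In this assay, removing the methyl alone gives a 1000-fold lower number from compound 3 to compound 4 (3.00 log units; beyond the scatter), so a single carbon at this place on the ring, meta to a large group, accounts for a large step, which the earlier whole-aryl replacements could not show. The plain phenyl also stands apart from the other aryl groups: phenyl in place of 2,4,6-trichlorophenyl gives a 10-fold lower number from compound 2 to compound 4 (1.00 log units; beyond the scatter), and hydrogen in place of nitro gives a 100-fold lower number from compound 1 to compound 4 (2.00 log units; beyond the scatter), which leaves compound 4 with the lowest number of the four. Each of the three substituted aryl groups shown therefore carries a higher number than the plain phenyl, and the 3-methylphenyl of compound 3 stands highest, above even the 2,4,6-trichlorophenyl of compound 2. Nothing available explains why one methyl should carry so large a step.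

It remains open whether the step belongs to the methyl itself or to its place on the ring, since a methyl elsewhere on the ring does not appear among these compounds. On these data alone, it also remains open whether a single fluorine, a methoxy or an amine at this place would follow the methyl or stay close to the plain phenyl.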